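Fluoro for trifluoromethyl on the fused core

The source may hold more compounds than are shown below. What is called first, only, known or untested is meant among the compounds shown, and "the series" means these compounds.

Measured so far in an ADME assay on microsomes from liver (Rattus norvegicus, strain Wistar) for metabolic stability, tested at 2.5 uM; a higher number here means faster removal of the compound, a lower number slower removal:
- compound 1, `Brc1ccc(Cn2nnc3c(Br)cccc32)cn1`: "not determined" (no result reported)
- compound 2, `FC(F)(F)c1cc(Br)c2nnn(CC3CC3)c2c1`: 0.2 mL/min/g

Among the compounds with values here, compound 2 is the only member of the series with a number in this assay; for compound 1 no single number was reported, so compound 2 cannot be placed relative to anything else. On its own, compound 2 gives 0.2 mL/min/g in this assay, a low intrinsic clearance.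

The next compound, compound 3, `Fc1cc(Br)c2nnn(CC3CC3)c2c1`, differs from compound 2 in one place: fluoro in place of trifluoromethyl on an aromatic carbon. Within the data shown here, no step between two measured compounds is available to calibrate what this exchange does in this assay, so the expectation rests on compound 2 alone and on the size of the exchange, which removes four heavy atoms and puts one in their place.

The expected step in this assay is a 1.5-fold higher number from compound 2 to compound 3 (0.18 log units; within the scatter), which is not expected to exceed the usual scatter of repeated measurements. Compound 3 is estimated at 0.3 mL/min/g in this assay, with a range from 0.1 mL/min/g to 1 mL/min/g.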

Compound 3, intrinsic clearance in a liver preparation (reported as CLH), per the amount of preparation that the assay uses: 0.5 mL/min/g
Estimate against measurement, compound 3: 1.7-fold (0.22 log units) below; the range from low to high includes it.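

In this assay, the place on the aromatic carbon, meta to a bromo group, now has its first calibrated exchange: fluoro in place of trifluoromethyl gives a 2.5-fold higher number from compound 2 to compound 3 (0.40 log units; beyond the scatter), a modest move that lies beyond the usual scatter of repeated measurements. The two compounds differ in this one place only, so the step can be assigned to the exchange itself, with the fluoro compound on the side of faster removal, and it shows that the read-out is sensitive to what sits at this position. No measurement at hand bears on why the number moves with this exchange.

As far as these compounds go, a single step sets no trend, and whether an exchange of the same kind would give a similar step at another place on the shared core, or with a different group in place of the bromo group, stays open. Also open, from the compounds shown here alone, is where other groups at this same place, such as a nitrile, a methoxy group or an amine, would fall relative to trifluoromethyl and fluoro in this assay.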